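Replacing the chloromethyl amide with a chloropyridine carboxamide

A few compounds are considered here, and "the series" means these few. Any claim that something is new, unique, unknown or untested is made for them only; others in the source may bear on it.

Measured compounds:
- compound 1, `C=CC(=O)Nc1cccc(-c2nc3ccccc3s2)c1`: > 25000 nM in an ADME assay on HEK293 cells (Homo sapiens) for inhibition, with a stated time of 72 h; a lower number here means that less compound is needed, a higher number that more compound is needed for the effect
- compound 2, `C/C=C/C(=O)Nc1cccc(-c2nc3ccccc3s2)c1`: > 25000 nM in this assay
- compound 3, `O=C(CCl)Nc1cccc(-c2nc3ccccc3s2)c1`: 10000 nM in this assay

The value given for compound 1 is a limit of the assay, not a number. The value given for compound 2 is likewise a limit. Within the data shown here, compound 3 therefore stands as the only compound of the three with a measured number in this assay; the two further values shown are limits.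

Compound 4, `O=C(Nc1cccc(-c2nc3ccccc3s2)c1)c1cccnc1Cl`, differs from compound 3 in one place: 2-chloropyridin-3-yl in place of chloromethyl on a carbonyl carbon.

Among the measured compounds shown here, two measured steps bear on this change, since both end at the chloromethyl group that now leaves. From compound 1 to compound 3 the step was an at least 2.5-fold lower number from compound 1 to compound 3 (0.39 log units; beyond the scatter), and from compound 2 to compound 3 it was an at least 2.5-fold lower number from compound 2 to compound 3 (0.39 log units; beyond the scatter). Both are at least modest lowerings when chloromethyl enters on the carbonyl carbon, so its departure in compound 4 is expected to reverse that, giving a higher number; the exact size cannot be read because of the limit of > 25000 nM in this assay, at which 2 of the 3 values shown sit.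

Compound 4 is therefore expected at about 30000 nM, in the range 8000 nM to 120000 nM. This estimate means a step of a 3.0-fold higher number from compound 3 to compound 4 (0.48 log units; beyond the scatter) from compound 3 to compound 4, and the assay may well report only a limit.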

Compound 4, half-maximal effective concentration: > 25000 nM
Compound 4 gave a limit, no number; the forecaster's own chance of this, stated with the estimate: 70%; the middle value lies beyond the limit too.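

In this assay, putting 2-chloropyridin-3-yl in place of chloromethyl on the carbonyl carbon gives an at least 2.5-fold higher number from compound 3 to compound 4 (0.39 log units; beyond the scatter). Both groups carry a chlorine, so among these compounds a chlorine in the group on the carbonyl carbon is not enough to give a measured number, and a six-membered aromatic ring now joins vinyl and prop-1-en-1-yl among the groups that end at the limit. Compound 3 remains the only one of the four with a number, and the steps from compound 1 and from compound 2 to compound 4 cannot be read because all three of these values are limits: the limit of > 25000 nM in this assay, at which 3 of the 4 values shown sit.

Going by these compounds, how far compound 1, compound 2 and compound 4 actually lie from one another stays open. Also open, on these data alone, is how a bromomethyl group, a longer chain such as 2-chloroethyl, or a pyridin-3-yl ring without its chlorine would read out on the shared core.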